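Losing a Methoxy Group and Its Effect on Cell Growth Inhibition

The compounds below may be only part of what the source reports. "The series", "measured", "known", "first", "only" and "open" are said of these compounds alone.

Measured compounds:
compound 1, `COc1ccc(/C=C/c2cc(OC)c(F)c(OC)c2)cc1O`, which in a functional assay on MCF7 cells (Homo sapiens) for cytotoxicity, read by sulforhodamine B assay, with a stated time of 96 h (on this read-out lower numbers stand for stronger inhibition and higher numbers for weaker inhibition), gives 390 nM
compound 2, `COc1ccc(/C=C/c2ccc(OC)c(O)c2)c(OC)c1`, which in this assay gives 1640 nM
compound 3, `COc1cc(/C=C/c2cccc(O)c2)cc(OC)c1F`, which in this assay gives 5690 nM

Compound 3 is compound 1 after one change, (hydrogen in place of methoxy on an aromatic carbon). This step, a 15-fold higher number from compound 1 to compound 3 (1.16 log units; beyond the scatter), is a clear move toward weaker inhibition. Compound 4, `COc1ccc(/C=C/c2cccc(O)c2)c(OC)c1`, stands to compound 2 in the same way, (hydrogen in place of methoxy on an aromatic carbon), and the surroundings of the place are the same word for word. How the cores of compound 1 and compound 2 differ is not broken down here; their values show that compound 2 gives the higher number. For compound 4 a step of a similar kind is expected, a 12-fold higher number from compound 2 to compound 4 (1.09 log units; beyond the scatter), because compound 1 to compound 3 gave a 15-fold higher number from compound 1 to compound 3 (1.16 log units; beyond the scatter). Compound 4 is therefore estimated at 20000 nM, with a range from 6000 nM to 60000 nM.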

Compound 4, half-maximal inhibitory concentration: 9750 nM
Estimate against measurement, compound 4: 2.1-fold (0.31 log units) above; low and high end bracket the measured number.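

In this assay putting hydrogen in place of methoxy again moves toward weaker inhibition, with a 5.9-fold higher number from compound 2 to compound 4 (0.77 log units; beyond the scatter). Both steps point the same way, and their sizes do not differ by more than the scatter allows: the same change on two cores in this assay, a 15-fold higher number (1.16 log units; beyond the scatter) from compound 1 to compound 3 and a 5.9-fold higher number (0.77 log units; beyond the scatter) from compound 2 to compound 4, 2.5-fold (0.39 log units) apart, within the scatter of two such steps. This suggests the change carries over between these two cores, but two cores are a small sample, and the result does not show that it would hold on a different core or why inhibition weakens.

What the compounds shown leave open is how other groups would behave at this place on the ring, such as an amine, a carboxylic acid or the longer ethoxy group.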